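Putting a sulfonyl group on compound 2

The source may hold more compounds than are shown below. What is called first, only, known or untested is meant among the compounds shown, and "the series" means these compounds.

In a functional assay on SMMC-7721 cells (Homo sapiens) for cytotoxicity, read by MTT assay, with a stated time of 24 h (a higher number here means a weaker inhibitor, a lower number a stronger inhibitor), compound 1 `CN1C/C(=C\c2ccncc2)C(=O)/C(=C/c2ccccc2C(F)(F)F)C1` gives 4100 nM. Compound 2 `O=C1/C(=C/c2cccnc2)CNC/C1=C\c1ccccc1F` gives > 20000 nM, which is a limit of the assay and not a number. Compound 3 `O=C1/C(=C/c2cccnc2)CN(S(=O)(=O)c2ccc(F)cc2)C/C1=C\c1ccccc1F` is compound 2 with (4-fluorophenyl)sulfonyl in place of hydrogen on an amine nitrogen in a ring. Among the compounds with values here, only one true number exists here, compound 1 at 4100 nM, so the expectation of stronger inhibition rests on thin ground. The expected change is an at least 4.0-fold lower number from compound 2 to compound 3 (0.60 log units; beyond the scatter), towards stronger inhibition in this assay. For compound 3 the estimate is 5000 nM, with an expected range from 1500 nM to 18000 nM.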

Compound 3, half-maximal inhibitory concentration: 9900 nM
The estimate for compound 3 lay 2.0-fold (0.30 log units) below the measured number, within the range that was stated.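

In this assay, (4-fluorophenyl)sulfonyl on the amine nitrogen in a ring gives an at least 2.0-fold lower number from compound 2 to compound 3 (0.30 log units; that floor lies within the scatter). This position can therefore carry this sulfonyl group while compound 3 still gives a true number. The real size of the change cannot be read because one end of it is a limit: the limit of > 20000 nM in this assay, at which 1 of the 3 values shown sits.

On these data alone, what stays open is whether the sulfonyl link or the 4-fluorophenyl ring matters more. A methylsulfonyl or an acetyl group on the same nitrogen would help to separate the two.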